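The source may report more compounds than this note shows. Statements on the series, on what has been measured and on what is new or still open speak of the compounds shown alone.

Measured in a functional assay on the whole organism (Tail, strain ICR) with Mus musculus as the target, in the tail flick test, with a stated time of 120 min, at a dose of 25 umol/kg by the oral route; on this read-out lower numbers stand for a weaker effect and higher numbers for a stronger effect at the one dose given:
compound 1 `O=C(CN(c1nc(Cl)nc2[nH]cnc12)C1CC1)NCC(=O)OCc1ccccc1`: 21.7%
compound 2 `CC[C@H](C)[C@H](NC(=O)CN(c1nc(Cl)nc2[nH]cnc12)C1CC1)C(=O)O`: 21.4%

Compound 1 and compound 2 give numbers within the usual scatter of each other, so neither can be called stronger. Compound 3 `O=C(CN(c1nc(Cl)nc2[nH]cnc12)C1CC1)N[C@@H](CCC(=O)OCc1ccccc1)C(=O)OCc1ccccc1` differs from compound 1 in one place: 2-(benzyloxycarbonyl)ethyl in place of hydrogen on a saturated chain carbon bound to an amide-type nitrogen and a carbonyl carbon. Within the data shown here, no step between measured compounds is known that isolates such a change, but both measured compounds, one with an acid and one with a benzyl ester at that chain carbon, sit close together in this assay, which suggests a step no larger than the scatter, in either direction. Compound 3 is therefore expected to give about 22%, between 8% and 38%, an expected step of a number 0.3 percentage points higher from compound 1 to compound 3 (within the scatter).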

Compound 3, a percentage reported as activity, at one dose (the size of the read-out at that dose, not a potency): 45.9%
Estimate against measurement, compound 3: 23.9 percentage points below; measured number above the stated range.
By their numbers in this assay, from the lowest: compounds 2 and 1 (each within the scatter of the next); then compound 3.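

In this assay, among these compounds, 2-(benzyloxycarbonyl)ethyl in place of hydrogen on the saturated chain carbon gives a number 24.2 percentage points higher from compound 1 to compound 3 (beyond the scatter), the first step here that clearly exceeds the scatter. This position therefore accepts a substituent of this kind without loss of effect, and the read-out responds to what sits there. Nothing available explains the rise. As far as these compounds go, what remains open is which part of the group matters: a free carboxylic acid at the end of the same chain, or a plain ethyl group at that carbon, would help to separate the chain from the benzyl ester.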